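This account rests on a few compounds, and the source may have more. Where it says the series, first, only, none or still open, it means among the compounds named here.

Measured so far in a functional assay on DU-145 cells (Homo sapiens) for antiproliferative activity, read by WST assay, with a stated time of 3 days; on this read-out higher numbers stand for weaker inhibition and lower numbers for stronger inhibition:
- Compound 1 `CCCCCCOc1c(-c2cc(OC)c(OC)c(OC)c2)oc2ccccc2c1=O`: > 50000 nM (a limit)
- Compound 2 `CCC(C)Oc1c(-c2cc(OC)c(OC)c(OC)c2)oc2ccccc2c1=O`: > 50000 nM (a limit)
- Compound 3 `CCCN(CCC)CCCCCOc1c(-c2cc(OC)c(OC)c(OC)c2)oc2ccccc2c1=O`: 24200 nM

The starting point, compound 2, has no exact number. Compound 2 gives > 50000 nM, which is a limit of the assay. It shares this with compound 1, as the limit of > 50000 nM in this assay, at which 2 of the 3 values shown sit, shows.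

Compound 4 `CCCCN(CCCC)CCCOc1c(-c2cc(OC)c(OC)c(OC)c2)oc2ccccc2c1=O` has 3-(dibutylamino)propyl in place of sec-butyl on an oxygen on an aromatic ring.

The closest guide is compound 3, which carries 5-(dipropylamino)pentyl on that oxygen and gives 24200 nM. Among the compounds with values here, two measured steps bear on the change: an at least 2.0-fold lower number from compound 2 to compound 3 (0.31 log units; beyond the scatter) and an at least 2.0-fold lower number from compound 1 to compound 3 (0.31 log units; beyond the scatter). Both are minimum sizes, so the full steps could be larger. By contrast, a step that the two limits leave unreadable from compound 1 to compound 2 offers no guidance.

Compound 4 also carries a dialkylamino chain, so a drop of similar or somewhat greater size seems likely in this assay. The expected change is an at least 3.3-fold lower number from compound 2 to compound 4 (0.52 log units; beyond the scatter), towards stronger inhibition. For compound 4, the estimated value is 15000 nM, with an expected range from 4000 nM to 50000 nM.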

Compound 4, half-maximal inhibitory concentration: 15700 nM
The estimate for compound 4 lay 1.0-fold (0.02 log units) below the measured number; the measured number falls inside the stated range.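

In this assay, compound 4 shows that the gain seen with compound 3 is not confined to one chain, since a second dialkylamino chain on this oxygen also gives a change beyond the scatter against the plain alkyl ethers: an at least 3.1-fold lower number from compound 2 to compound 4 (0.50 log units; beyond the scatter), and an at least 3.1-fold lower number from compound 1 to compound 4 (0.50 log units; beyond the scatter). These two steps are only minimum sizes because compound 1 and compound 2 have no exact values: the limit of > 50000 nM in this assay, at which 2 of the 4 values shown sit. The two amine chains themselves cannot be told apart here, with a 1.5-fold lower number from compound 3 to compound 4 (0.19 log units; within the scatter).

Chain length and the alkyl groups on the nitrogen differ together between compound 3 and compound 4, so the part played by each remains unseparated. On these data alone, how a piperidine or a morpholine would read in place of the dibutylamino group also remains open.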